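Replacing a benzyl with a thiourea on the ring amine

The source may hold more compounds than are shown below. What is called first, only, known or untested is meant among the compounds shown, and "the series" means these compounds.

Compound 1, `NC(=O)c1c(NC(=O)c2ccccc2Cl)sc2c1CCN(Cc1c(Cl)cccc1Cl)C2`, was tested in a functional assay on HL-60 cells (Homo sapiens) for antiproliferative activity, with a stated time of 24 h (on this read-out higher numbers stand for weaker inhibition and lower numbers for stronger inhibition), where compound 1 gives 4850 nM. Among the two numbers recorded in this assay, this is the lowest. Compound 3, `NC(=O)c1c(NC(=O)c2cccc([N+](=O)[O-])c2)sc2c1CCN(Cc1c(Cl)cccc1Cl)C2`, gives 18400 nM in this assay. Compound 2, `NC(=O)c1c(NC(=O)c2ccc(C(F)(F)F)cc2)sc2c1CCN(Cc1ccc(Cl)cc1)C2`, reaches only the limit of this assay, > 50000 nM, so no number is known for compound 2 in this assay. Going by the values given here, the one measured step, a 3.8-fold higher number from compound 1 to compound 3 (0.58 log units; beyond the scatter), concerns the group on the carbonyl carbon of the amide and leaves the ring amine untouched.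

Compound 4, `NC(=O)c1c(NC(=O)c2ccccc2Cl)sc2c1CCN(C(=S)Nc1c(Cl)cccc1Cl)C2`, has not been measured. It differs from compound 1 in this way: a group of 11 heavy atoms (7 carbon, 1 nitrogen, 1 sulfur, 2 chlorine; one six-membered aromatic ring of carbon only) in place of a group of 9 heavy atoms (7 carbon, 2 chlorine; one six-membered aromatic ring of carbon only), on an amine nitrogen in a ring. Among the compounds with values here, no measured pair changes the group on this amine nitrogen, so the measured step from compound 1 to compound 3 does not bear on the change and gives no direction for it. The expectation for compound 4 therefore rests on compound 1 alone, with a wide range and no step beyond the scatter assumed in either direction. Compound 4 is expected to give 6000 nM in this assay, between 1500 nM and 30000 nM, which means an expected step of a 1.2-fold higher number from compound 1 to compound 4 (0.09 log units; within the scatter).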

Compound 4, half-maximal inhibitory concentration: 3950 nM
The estimate for compound 4 lay 1.5-fold (0.18 log units) above the measured number; the range from low to high includes it.
By their numbers in this assay, from the lowest: compounds 4 and 1 (each within the scatter of the next); then compound 3. At a limit, above all of these: compound 2.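

Going by these compounds alone, this is the first pair in which the group on the amine nitrogen in the ring changes, and in this assay the step is a 1.2-fold lower number from compound 1 to compound 4 (0.09 log units; within the scatter). With the 2-chlorophenyl on the carbonyl carbon held fixed, the 2,6-dichlorobenzyl of compound 1 can thus give way to the larger thiourea group of compound 4, which has 1 hydrogen-bond donor and 1 hydrogen-bond acceptor where the 2,6-dichlorobenzyl has 0 of each, without the number moving beyond the scatter. Nothing measured here speaks to why these two different groups give such similar numbers.

This single pair cannot show whether the thiourea would also match the 2,6-dichlorobenzyl when the 3-nitrophenyl of compound 3 sits on the carbonyl carbon. It also leaves open what a urea, with oxygen in place of the sulfur, a thiourea carrying a plain phenyl or a short alkyl chain, or a bare hydrogen on the ring amine would give in this assay.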